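Bromo in Place of Trifluoromethyl: An Expected Dose

The source may report more compounds than this note shows. Statements on the series, on what has been measured and on what is new or still open speak of the compounds shown alone.

Among the compounds with values here, compound 2 `FC(F)(F)c1ccc(-n2nncc2-c2cccnc2)cc1` is examined in a functional assay on the whole organism with Mus musculus as the target, in the maximal electroshock model (on this read-out higher numbers stand for an effect only at larger amounts of compound and lower numbers for an effect already at smaller amounts), where compound 2 gives 92.3 mg/kg, the highest of the two numbers measured so far. Compound 1 `Clc1ccc(-n2nncc2-c2cccnc2)cc1` gives 65.8 mg/kg in this assay, and the step of a 1.4-fold higher number from compound 1 to compound 2 (0.15 log units; within the scatter). Compound 3 `Brc1ccc(-n2nncc2-c2cccnc2)cc1` differs from compound 2 by bromo in place of trifluoromethyl on an aromatic carbon. Within the data shown here, the only measured step bearing on this change, a 1.4-fold higher number from compound 1 to compound 2 (0.15 log units; within the scatter), lies within the scatter, so compound 3 is expected to show no step beyond the scatter in this assay. The value expected for compound 3 is 75 mg/kg, with a range from 40 mg/kg to 140 mg/kg. This estimate means an expected step of a 1.2-fold lower number from compound 2 to compound 3 (0.09 log units; within the scatter).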

Compound 3, dose for half-maximal effect: 87.2 mg/kg
For compound 3 the middle estimate is 1.2-fold (0.07 log units) below the measured one; the measured number falls inside the stated range.
By their numbers in this assay, from the lowest: compounds 1, 3 and 2 (each within the scatter of the next).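

In this assay bromo at this aromatic carbon behaves like the two groups already seen there. With a 1.1-fold lower number from compound 2 to compound 3 (0.02 log units; within the scatter) and a 1.3-fold higher number from compound 1 to compound 3 (0.12 log units; within the scatter) the three groups now lie within the scatter of one another, and the exchange of bromo for either group shows no step beyond it. No measurement offered here accounts for this result.

On these data alone, whether an amine, a carboxylic acid or a longer chain on this carbon would stay in the same range remains open. So does the effect of plain hydrogen there.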